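Hydroxamic Acid in Place of Methylamide on a Long Chain

The source may report more compounds than this note shows. Statements on the series, on what has been measured and on what is new or still open speak of the compounds shown alone.

Measured compounds:
compound 1 `CNC(=O)CCCCCCCn1nc(-c2ccc3oc(N)nc3c2)c2c(N)ncnc21` — 2250 nM
compound 2 `Nc1ncnc2c1c(-c1cnc3[nH]ccc3c1)nn2CCCC(=O)NO` — > 150000 nM

In a functional assay on CNE-2 cells (Homo sapiens) for inhibition, read by MTT assay, with a stated time of 72 h (on this read-out higher numbers stand for weaker inhibition and lower numbers for stronger inhibition), compound 1 gives 2250 nM, the only plain number among the two results shown. Among the compounds with values here, compound 2, in this assay, gives only a limit, > 150000 nM, and it stands at the limit of > 150000 nM in this assay, at which 1 of the 2 values shown sits; no step between compound 1 and compound 2 is described, so their two values say only that one is a number and the other a limit.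

Compound 3 `Nc1nc2cc(-c3nn(CCCCCCCCC(=O)NO)c4ncnc(N)c34)ccc2o1` has not yet been measured in this assay. It differs from compound 1 in a single place: (hydroxycarbamoyl)methyl in place of methylcarbamoyl on a saturated chain carbon, seven bonds along the chain from an aromatic nitrogen. Within the data shown here, with no measured step of this kind to rest on, the size and direction of the change are uncertain. The expected step from compound 1 to compound 3 is a 1.9-fold lower number from compound 1 to compound 3 (0.27 log units; within the scatter), a modest gain that may not rise beyond the usual scatter. Compound 3 is therefore estimated at 1200 nM, within a range from 300 nM to 6000 nM.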

Compound 3, half-maximal inhibitory concentration: 3240 nM
Beside the measured number, compound 3's estimate is 2.7-fold (0.43 log units) below it; low and high end bracket the measured number.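

Within the data shown here, this is the first measured step at this position: in this assay, putting (hydroxycarbamoyl)methyl in place of methylcarbamoyl on the saturated chain gives a 1.4-fold higher number from compound 1 to compound 3 (0.16 log units; within the scatter). On this long chain and this shared core, the hydroxamic acid end and the methylamide end therefore cannot be told apart in this assay. No measurement shown bears on why the change leaves the number within the scatter.

Still open, as far as these compounds go, is whether a carboxylic acid at the end of the same chain would also read alike, and whether a longer chain carrying the hydroxamic acid would do so. Compound 2 has a shorter chain, but it differs from compound 3 in more than one place, so it cannot settle the effect of chain length.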